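The source may hold more compounds than are shown below. What is called first, only, known or untested is meant among the compounds shown, and "the series" means these compounds.

Of the compounds shown here, three sharing one core have been tested in a functional assay on MCF7 cells (Homo sapiens) for inhibition, read by MTT assay, with a stated time of 48 h, tested at 10 uM; on this read-out higher numbers stand for more inhibition of growth at the one concentration tested and lower numbers for less inhibition of growth. Compound 1 `Cc1cc(=O)c2c(O)cc(OCc3ccco3)c([C@H]3CCN(C)C[C@H]3O)c2o1` gives 6%, compound 2 `Cc1cc(=O)c2c(O)c(CN3CCCC3)c(O)c([C@H]3CCN(C)C[C@H]3O)c2o1` gives 12%, and compound 3 `Cc1cc(=O)c2c(O)c(CN3CCN(C(=O)OC(C)(C)C)CC3)c(O)c([C@H]3CCN(C)C[C@H]3O)c2o1` gives 16%. The number for compound 2 lies within the scatter of both others, so the three are not separated. Compound 4 `Cc1cc(=O)c2c(O)c(CN3CCCC3C(=O)O)c(O)c([C@H]3CCN(C)C[C@H]3O)c2o1` carries carboxy in place of hydrogen on a saturated ring carbon of the pyrrolidin-1-yl group of compound 2 (carboxy in place of hydrogen on a saturated ring carbon). Within the data shown here, no measured pair shows what such a change does, so no step beyond the scatter is expected in this assay. The estimate is a number 2 percentage points lower from compound 2 to compound 4 (within the scatter), a step within the scatter. Compound 4 is expected at 10%, with an estimated range from 0% to 24%.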

Compound 4, percent growth inhibition at one concentration: 21%
Compound 4: middle estimate off by 11 percentage points, on the low side, and the stated range covers the measured number.
By their numbers in this assay, from the lowest: compounds 1, 2, 3 and 4 (each within the scatter of the next, the first and the last beyond it).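

In this assay, carboxy in place of hydrogen on a saturated ring carbon, next to the ring nitrogen, gives a number 9 percentage points higher from compound 2 to compound 4 (within the scatter) and so leaves the read-out within the scatter at this position. Among these compounds, the earlier compounds held no pair differing at this place, so this is the first reading of such a change here. Nothing measured on these compounds bears on the result. Open, as far as these compounds go, is whether a methyl ester, a primary amide or an aminomethyl group on this ring carbon would read differently, and whether carboxy elsewhere on the pyrrolidin-1-yl group would match it.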